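From 4-fluoro-3-methylphenyl to 3,4-dihydroxyphenyl in compound 3

This account rests on a few compounds, and the source may have more. Where it says the series, first, only, none or still open, it means among the compounds named here.

Compound 1 `CSc1ccc(C2=C(c3ccc(F)c(F)c3)C(=O)N3CCCC3C2)cc1`: 100 nM
Compound 2 `CSc1ccc(C2=C(c3ccc(F)c(C)c3)C(=O)N3CCCC3C2)cc1`: 300 nM

In a functional assay on SK-OV-3 cells (Homo sapiens) for cytotoxicity (a higher number here means a weaker inhibitor of growth, a lower number a stronger inhibitor of growth), compound 2 gives 300 nM, the higher of the two numbers and so the weaker inhibitor of growth. Compound 3 `CSc1ccc(C2=C(c3ccc(O)c(O)c3)C(=O)N3CCCC3C2)cc1` is still unmeasured. It has 3,4-dihydroxyphenyl in place of 4-fluoro-3-methylphenyl on a double-bonded ring carbon. Going by the values given here, only one measured step touches this group, a modest one: a 3.0-fold higher number from compound 1 to compound 2 (0.48 log units; beyond the scatter). Among the compounds with values here, no measured compound carries a 3,4-dihydroxyphenyl group, so the direction is uncertain, and a small rise at most seems the fair expectation. The expected change is a 1.3-fold higher number from compound 2 to compound 3 (0.12 log units; within the scatter), which would not stand beyond the scatter. Compound 3 is estimated at 400 nM, with an expected range of 80 nM to 2000 nM.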

Compound 3, concentration for 50% growth inhibition: 80000 nM
The estimate for compound 3 lay 200-fold (2.30 log units) below the measured number; the whole stated range lies below it.
By their numbers in this assay, from the lowest: compound 1; then compound 2; then compound 3.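

In this assay the group on the double-bonded ring carbon matters far more than the swap of fluoro for methyl suggested: 3,4-dihydroxyphenyl brings a 270-fold higher number from compound 2 to compound 3 (2.43 log units; beyond the scatter) and an 800-fold higher number from compound 1 to compound 3 (2.90 log units; beyond the scatter) while the rest of the molecule stays the same. This position therefore does not treat all substituted phenyl groups alike, and the entering group carries hydrogen-bond donors and acceptors that 4-fluoro-3-methylphenyl lacks.

As far as these compounds go, both hydroxyl groups arrive together, so whether a single hydroxyl, or methoxy groups in their place, would cost as much stays open. Nothing measured here gives a reason for the drop.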